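This account rests on a few compounds, and the source may have more. Where it says the series, first, only, none or still open, it means among the compounds named here.

Of the compounds shown here, three have been measured in a functional assay on HT-29 cells (Homo sapiens) for inhibition, read by MTT assay, with a stated time of 72 h; on this read-out lower numbers stand for stronger inhibition and higher numbers for weaker inhibition. Compound 3 `CN(C)CCn1c(=O)c(=Cc2ccc(F)cc2F)s/c1=C1\C(=O)Nc2cc(F)ccc21` gives 6460 nM. Compound 1 `CN(C)CCn1c(=O)c(=Cc2ccc(F)c(F)c2)s/c1=C1\C(=O)Nc2cc(F)ccc21` gives 12100 nM, and the change a 1.9-fold lower number from compound 1 to compound 3 (0.27 log units; within the scatter) shows that the two sit within the scatter of each other. Compound 2 `CCN(CC)CCCn1c(=O)c(=Cc2ccccc2O)s/c1=C1\C(=O)Nc2ccc(Br)cc21` gives 18100 nM, a higher number than compound 3 and beyond the scatter.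

Compound 4 `COc1ccc(C=c2s/c(=C3\C(=O)Nc4cc(F)ccc43)n(CCN(C)C)c2=O)cc1` differs from compound 3 by a single change: 4-methoxyphenyl in place of 2,4-difluorophenyl on a double-bonded chain carbon bound to an aromatic carbon. Going by the values given here, the only step measured at this place is a 1.9-fold lower number from compound 1 to compound 3 (0.27 log units; within the scatter), which swaps one fluorine pattern for another and did not move the number beyond the scatter. Among the compounds with values here, no measured step shows a methoxyphenyl entering, so the step of a 1.2-fold higher number from compound 3 to compound 4 (0.09 log units; within the scatter) is expected to be small. Compound 4 is therefore estimated at 8000 nM, with a range from 2500 nM to 25000 nM.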

Compound 4, half-maximal inhibitory concentration: 2300 nM
Compound 4: the middle estimate sits 3.5-fold (0.54 log units) above what was measured; measured number outside the range, below it.
By their numbers in this assay, from the lowest: compound 4; then compounds 3, 1 and 2 (each within the scatter of the next, the first and the last beyond it).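

Swapping one fluorine pattern for the other had left the number within the scatter, which made this place on a double-bonded chain carbon bound to an aromatic carbon look insensitive. Bringing in 4-methoxyphenyl gives a 2.8-fold lower number from compound 3 to compound 4 (0.45 log units; beyond the scatter) and a 5.3-fold lower number from compound 1 to compound 4 (0.72 log units; beyond the scatter) with the rest of the molecule unchanged, so the group here can shift the number beyond the scatter. Going by these compounds, whether the lower number follows the oxygen or the loss of fluorine remains open, as would be tested by a methyl group or an amine in place of the methoxy group. No measurement at hand explains why this change lowers the number.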